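Sulfonyl for carbonyl swap at two chain lengths

This account rests on a few compounds, and the source may have more. Where it says the series, first, only, none or still open, it means among the compounds named here.

Compound 1 `C/C=C/C=C/C(=O)N[C@H](C(=O)NCCCCCCCCCCCCCC)[C@@H](C)O` carries a (penta-1,3-dien-1-yl)carbonyl on the amine nitrogen and a long saturated amide chain. In a functional assay on SiHa cells (Homo sapiens) for cytotoxicity, read by MTT assay, with a stated time of 48 h (a lower number here means a stronger inhibitor, a higher number a weaker inhibitor), compound 1 gives only a limit, > 200000 nM. Compound 2 `CCCCCCCCCCCCCCNC(=O)[C@@H](NS(=O)(=O)c1ccc(C)cc1)[C@@H](C)O` differs in one place: (4-methylphenyl)sulfonyl in place of (penta-1,3-dien-1-yl)carbonyl on an amine nitrogen. In this assay compound 2 gives 19200 nM. The step is an at least 10-fold lower number from compound 1 to compound 2 (1.01 log units; beyond the scatter); its size rests on (the limit of > 200000 nM in this assay, at which 2 of the 3 values shown sit), so only its lower bound is known.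

Compound 3 `C/C=C/C=C/C(=O)N[C@H](C(=O)NCCCCCCCCCCCCCCCCCC)[C@@H](C)O` lengthens the amide chain: butyl in place of hydrogen on a saturated chain carbon, ten or more bonds along the chain from an amide-type nitrogen. In this assay compound 3 gives only a limit, > 200000 nM. The step that the two limits leave unreadable from compound 1 to compound 3 therefore cannot be read, and both compounds sit at the limit of > 200000 nM in this assay, at which 2 of the 3 values shown sit.

Compound 4 `CCCCCCCCCCCCCCCCCCNC(=O)[C@@H](NS(=O)(=O)c1ccc(C)cc1)[C@@H](C)O` is not yet measured. It relates to compound 3 as compound 2 relates to compound 1: (4-methylphenyl)sulfonyl in place of (penta-1,3-dien-1-yl)carbonyl on an amine nitrogen. The place line is word for word the same in both pairs, so this is the same change, made twice in the series. The expectation for the step from compound 3 to compound 4 is an at least 6.6-fold lower number from compound 3 to compound 4 (0.82 log units; beyond the scatter), set beside an at least 10-fold lower number from compound 1 to compound 2 (1.01 log units; beyond the scatter), and rests on compound 2 having given 19200 nM. As far as these compounds go, compound 3, like compound 1, starts at a limit, so the starting point of this step is unknown. Compound 4 is estimated at 30000 nM, between 10000 nM and 150000 nM, with a fair chance that this assay again returns only a limit.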

Compound 4, half-maximal inhibitory concentration: 29800 nM
For compound 4 the middle estimate is 1.0-fold (0.00 log units) above the measured one; the measured number falls inside the stated range.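

With (4-methylphenyl)sulfonyl in place of (penta-1,3-dien-1-yl)carbonyl on the amine nitrogen, this assay shows an at least 6.7-fold lower number from compound 3 to compound 4 (0.82 log units; beyond the scatter), so the direction of the change seen on the shorter amide chain holds on the longer one. Set beside the earlier pair, the two steps read as follows: the same change on two cores in this assay, an at least 10-fold lower number (1.01 log units; beyond the scatter) from compound 1 to compound 2 and an at least 6.7-fold lower number (0.82 log units; beyond the scatter) from compound 3 to compound 4; the limit leaves it open whether they differ This shows a shared direction on the two cores but no shared size, since both steps start from a limit rather than a number: the limit of > 200000 nM in this assay, at which 2 of the 4 values shown sit.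

As far as these compounds go, the butyl step can be read only between the two (4-methylphenyl)sulfonyl compounds, a 1.6-fold higher number from compound 2 to compound 4 (0.19 log units; within the scatter), while the same step between the two (penta-1,3-dien-1-yl)carbonyl compounds cannot be read, so any effect of chain length on the carbonyl side remains open. Also open, from the compounds shown here alone, is whether the change carries to a much shorter amide chain, and whether other groups on the amine nitrogen, such as a benzoyl, a methylsulfonyl or an unsubstituted phenylsulfonyl, would give numbers like those of compound 2 and compound 4.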